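A few compounds are considered here, and "the series" means these few. Any claim that something is new, unique, unknown or untested is made for them only; others in the source may bear on it.

Measured compounds: compound 1 `CN(C(=O)CNC(=O)CN)c1ccc(Cl)cc1C(=O)c1ccccc1Cl` gives 0.58 mg/kg in a functional assay on the whole organism for antagonist activity, with Mus musculus as the target; a higher number here means that more compound is needed for the effect, a lower number that less compound is needed; compound 2 `CCCCCCC(=O)NCC(=O)N(C)c1ccc(Cl)cc1C(=O)c1ccccc1Cl` gives 1.9 mg/kg.

Compound 2 stands at the higher of the two numbers, and the step of a 3.3-fold higher number from compound 1 to compound 2 (0.52 log units; beyond the scatter) separates it from compound 1 beyond the scatter. Compound 3 `CCCCCCCCCCCCCCCC(=O)NCC(=O)N(C)c1ccc(Cl)cc1C(=O)c1ccccc1Cl` differs from compound 2 by nonyl in place of hydrogen on a saturated chain carbon, six bonds along the chain from a carbonyl carbon. Among the measured compounds shown here, the only measured step that bears on this change is a 3.3-fold higher number from compound 1 to compound 2 (0.52 log units; beyond the scatter), where lengthening the same chain raised the number modestly; a further lengthening is therefore expected to raise the number in this assay again, by a modest to moderate amount. Compound 3 is expected to give 5 mg/kg, within 2 mg/kg to 15 mg/kg, an expected step of a 2.6-fold higher number from compound 2 to compound 3 (0.42 log units; beyond the scatter).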

Compound 3, dose for half-maximal effect: > 100 mg/kg
Compound 3 was reported as a limit (the forecaster's own chance of this, stated with the estimate: 25%); middle value at least 20-fold (1.30 log units) away from the limit.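

Adding nonyl in place of hydrogen on a saturated chain carbon, six bonds along the chain from a carbonyl carbon, gives an at least 52-fold higher number from compound 2 to compound 3 (1.72 log units; beyond the scatter) in this assay. The earlier step, a 3.3-fold higher number from compound 1 to compound 2 (0.52 log units; beyond the scatter), was only modest, so it did not show how sharply this chain position can respond to a longer chain. The reading for compound 3 is a limit of the assay, not a number: the limit of > 100 mg/kg in this assay, at which 1 of the 3 values shown sits.

It remains open where along the chain the rise sets in, since no chain of intermediate length is shown. As far as these compounds go, it is also open whether an amine or a carboxylic acid on the long chain would bring the number back down.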